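Swapping methyl position on the alkyne-linked phenyl ring

A few compounds are considered here, and "the series" means these few. Any claim that something is new, unique, unknown or untested is made for them only; others in the source may bear on it.

Of the compounds shown here, two have been measured in an assay on HEK293 cells for displacement of a labelled ligand from metabotropic glutamate receptor 5 (Homo sapiens), with a stated time of 2 h; a lower number here means a stronger inhibitor, a higher number a weaker inhibitor. Compound 1 `O=C(NC1CCCC1)c1ccc(C#Cc2ccccc2)nc1` carries a cyclopentyl amide on one side of its core and an unsubstituted phenyl across the triple bond; in this assay compound 1 gives 3300 nM. Compound 2 `Cc1ccccc1C#Cc1ccc2c(n1)CCN(C)C2=O` has a different core, a bicyclic lactam bearing a methyl on nitrogen, and a 2-methylphenyl on the triple bond. For compound 2 this assay returns only a limit, > 32000 nM, so its true value is not known as a number. Compound 2 therefore sits at the limit of the assay (the limit of > 32000 nM in this assay, at which 1 of the 2 values shown sits), the weaker end of what has been seen so far.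

Compound 3 `Cc1ccc(C#Cc2ccc3c(n2)CCN(C)C3=O)cc1` keeps the same core and the same atoms as compound 2 and differs only in one place: 4-methylphenyl in place of 2-methylphenyl on a triple-bonded carbon. Within the data shown here, no step between measured compounds shows what this kind of change does. With compound 2 at the limit, the step from compound 2 to compound 3 is expected to be an at least 2.1-fold lower number from compound 2 to compound 3 (0.32 log units; beyond the scatter) at most modest. Compound 3 is estimated to reach about 15000 nM, in a range from 3000 nM to 60000 nM.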

Compound 3, inhibition constant: 7450 nM
Beside the measured number, compound 3's estimate is 2.0-fold (0.30 log units) above it; measured number inside the range.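

Among these compounds, compound 2 and compound 3 hold the same atoms and differ in one place, so this pair is the first to isolate a single change. In this assay, 4-methylphenyl in place of 2-methylphenyl on a triple-bonded carbon gives an at least 4.2-fold lower number from compound 2 to compound 3 (0.63 log units; beyond the scatter). The methyl therefore cannot be moved around this ring freely on the shared core, although the size of the step remains a lower bound, because one end of it is a limit of the assay and not a number: the limit of > 32000 nM in this assay, at which 1 of the 3 values shown sits.

As far as these compounds go, compound 1, at 3300 nM, differs from compound 3 in more than one place, so the two cannot be compared, and it remains open how a plain phenyl would fare on the core of compound 2 and compound 3. Also open, from the compounds shown here alone, is whether a chlorine, a methoxy group or a longer chain such as ethyl, in place of the methyl of 4-methylphenyl, would give a lower or a higher number than compound 3.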